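The compounds below may be only part of what the source reports. "The series", "measured", "known", "first", "only" and "open" are said of these compounds alone.

Of the compounds shown here, two on a shared core, compound 1 (`Cc1cc(=O)c2c(OC[C@H]3CO3)cc(OC[C@H]3CO3)cc2o1`) and compound 2 (`Cc1cc(=O)c2c(O)cc(OC[C@@H]3CO3)cc2o1`), have numbers so far in a functional assay on K562 cells (Homo sapiens) for antiproliferative activity, with a stated time of 48 h; on this read-out higher numbers stand for weaker inhibition and lower numbers for stronger inhibition. There compound 1 gives 7860 nM and compound 2 gives 8030 nM. These values lie within the usual scatter of repeated measurements, so compound 2 stands level with compound 1.

The untested compound 3 (`Cc1cc(=O)c2c(OC[C@H]3CO3)cc(OC[C@@H]3CO3)cc2o1`) differs from compound 2 by one change: (oxiran-2-yl)methyl in place of hydrogen on an oxygen on an aromatic ring. In words, (oxiran-2-yl)methyl sits in place of hydrogen on an oxygen on an aromatic ring. Within the data shown here, no pair of measured compounds differing in one place is available, so the size of this change has not been seen directly in this assay. Among the measured compounds shown here, the only guide is that compound 1 at 7860 nM and compound 2 at 8030 nM sit level, which points in neither direction. No step beyond the scatter is therefore expected, although two values make a thin basis and the range must stay wide.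

Compound 3 is estimated at 7000 nM, with an expected range from 2800 nM to 18000 nM. This estimate means an expected 1.1-fold lower number from compound 2 to compound 3 (0.06 log units; within the scatter).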

Compound 3, half-maximal inhibitory concentration: 40 nM
The estimate for compound 3 lay 180-fold (2.24 log units) above the measured number; measured number outside the range, below it.
By their numbers in this assay, from the lowest: compound 3; then compounds 1 and 2 (each within the scatter of the next).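

In this assay, placing (oxiran-2-yl)methyl in place of hydrogen on an oxygen on an aromatic ring gives a 200-fold lower number from compound 2 to compound 3 (2.30 log units; beyond the scatter), so this position can strongly affect inhibition, which the level values of the two earlier compounds could not reveal. The new group is not enough by itself, however, since compound 1 has the same atoms and bonds as compound 3, yet the data show a 200-fold lower number from compound 1 to compound 3 (2.29 log units; beyond the scatter). This large gain in inhibition therefore depends on the three-dimensional arrangement as well as on the group, and the difference between these two compounds can be traced to configuration alone because of this: the fact that compounds 1 and 3 differ only in the configuration as drawn

From the compounds shown here alone, it remains open whether the three-membered ring is needed at this oxygen, or whether a plain methyl, a longer chain or an amine in the same place would also give strong inhibition. The compounds shown also leave open how the other possible combinations of configuration at the two stereo elements would behave, so the preferred arrangement is known only from the comparison of compound 1 with compound 3.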